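Swapping a trifluoromethyl for chloro on the pendant aryl

The source may report more compounds than this note shows. Statements on the series, on what has been measured and on what is new or still open speak of the compounds shown alone.

In a functional assay on MCF7 cells (Homo sapiens) for antiproliferative activity, read by MTT assay, with a stated time of 72 h (a higher number here means a weaker inhibitor, a lower number a stronger inhibitor), compound 1, `COc1cc(-n2cnc3ccc(-c4ccc(C(F)(F)F)cc4)cc32)cc(OC)c1OC`, gives 760 nM. This is the only plain number among the results shown; the other entry is a limit of the assay rather than a measured value. Compound 2, `COc1cc(-c2ccc3ncn(-c4cc(OC)c(OC)c(OC)c4)c3c2)cc(OC)c1OC`, is reported in this assay only as > 10000 nM, which is a limit and not a number, and it is described by the limit of > 10000 nM in this assay, at which 1 of the 2 values shown sits.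

Compound 3, `COc1cc(-n2cnc3ccc(-c4ccc(Cl)cc4)cc32)cc(OC)c1OC`, has not yet been measured in this assay. It is related to compound 1 by one alteration:

chloro in place of trifluoromethyl on an aromatic carbon

Among the measured compounds shown here, no measured pair in this set differs in only one place, so there is no recorded step to lean on for the size of this change. Both groups are without hydrogen-bond donors or acceptors and carry no net charge, and the exchange leaves the rest of compound 1 untouched. On that basis compound 3 is expected to sit close to compound 1, with any step a 1.2-fold higher number from compound 1 to compound 3 (0.07 log units; within the scatter) at most modest and possibly within the usual scatter. Compound 3 is therefore estimated at 900 nM, with a range from 350 nM to 2500 nM.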

Compound 3, half-maximal inhibitory concentration: 1320 nM
The estimate for compound 3 lay 1.5-fold (0.17 log units) below the measured number; low and high end bracket the measured number.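

The change now has a recorded size: in this assay the exchange gives a 1.7-fold higher number from compound 1 to compound 3 (0.24 log units; within the scatter) and so compound 1 and compound 3 cannot be ranked against each other. At this place, para to a large group on the pendant six-membered aromatic ring, a chloro of one heavy atom can therefore stand in for a trifluoromethyl of four heavy atoms without moving the read-out beyond the usual scatter of repeated measurements. No information on hand explains this outcome, and the only supporting entry, which concerns the assay limit reached by another compound, has no bearing on this pair.

The compounds shown leave open whether a quite different group at this place, such as an amine, a carboxylic acid or a nitrile, would keep the read-out where it is or shift it beyond the scatter. They also leave open whether chloro and trifluoromethyl would remain interchangeable on another aromatic carbon of the same ring or in a different cell line.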